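Removing the benzyl group from an acid ceramidase inhibitor

The compounds below may be only part of what the source reports. "The series", "measured", "known", "first", "only" and "open" are said of these compounds alone.

Compound 1 `CCN1CCN(c2ccc3c(c2)oc(=O)n3C(=O)NCCCCc2ccccc2)CC1`: 56 nM
Compound 2 `O=C(NCCCCc1ccccc1)n1c2c(oc1=O)CCN(Cc1ccccc1)C2`: 436 nM

Both compounds were tested in an assay on HEK293 cells for inhibition of acid ceramidase (Homo sapiens), read by fluorescence, with stated times of 10 min and 3 h; on this read-out higher numbers stand for weaker inhibition and lower numbers for stronger inhibition. Of these two numbers, compound 2 stands highest, and its nearest neighbour, compound 1, sits lower by a gap that lies beyond the usual scatter. Compound 3 `O=C(NCCCCc1ccccc1)n1c2c(oc1=O)CCNC2` differs from compound 2 in one place: hydrogen in place of benzyl on an amine nitrogen in a ring. Going by the values given here, no measured pair shows this change, so its effect has to be guessed. Compound 3 is expected to land at 1200 nM, within a range of 300 nM to 5000 nM. The step of a 2.8-fold higher number from compound 2 to compound 3 (0.44 log units; beyond the scatter) is expected to be modest, toward weaker inhibition, and may not clear the scatter.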

Compound 3, half-maximal inhibitory concentration: 247 nM
For compound 3 the middle estimate is 4.9-fold (0.69 log units) above the measured one, and the stated range ends above it.
By their numbers in this assay, from the lowest: compound 1; then compounds 3 and 2 (each within the scatter of the next).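

In this assay putting hydrogen in place of benzyl on the amine nitrogen in the ring gives a 1.8-fold lower number from compound 2 to compound 3 (0.25 log units; within the scatter) and so the whole benzyl group can leave without a shift that stands clear of the scatter. Going by these compounds alone, this is the first pair differing in one place, and it shows that, in this pair, inhibition does not hang on the benzyl group. Nothing measured here explains this result. Going by these compounds, it remains open whether a methyl or an acetyl group on this nitrogen would stay within the scatter of these two compounds or move the number beyond it.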